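The compounds below may be only part of what the source reports. "The series", "measured", "known", "first", "only" and "open" are said of these compounds alone.

Series notes, cytotoxicity on keratinocytes.

Compound 1 `Cc1cc(S(=O)(=O)/N=C(\N)N/N=C/C#Cc2ccccc2)c(SCc2ccccc2Cl)cc1Cl` carries a (2-chlorobenzyl)sulfanyl group beside the sulfonyl-bearing ring, with the unbranched alkynyl hydrazone on the amine nitrogen. In an ADME assay on HaCaT cells (Homo sapiens) for cytotoxicity, read by MTT assay, with a stated time of 72 h (a higher number here means a weaker inhibitor, a lower number a stronger inhibitor), compound 1 gives 25000 nM. Compound 2 `C/C(C#Cc1ccccc1)=N\N/C(N)=N/S(=O)(=O)c1cc(C)c(Cl)cc1SCc1ccccc1Cl` differs from compound 1 only at that amine nitrogen: a group of 11 heavy atoms (10 carbon, 1 nitrogen; one six-membered aromatic ring of carbon only) in place of a group of 10 heavy atoms (9 carbon, 1 nitrogen; one six-membered aromatic ring of carbon only), on an amine nitrogen. This change brings a 14-fold higher number from compound 1 to compound 2 (1.13 log units; beyond the scatter), so compound 2 in this assay gives 340000 nM, the highest number of the three measured compounds.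

Compound 3 `Cc1cc(S(=O)(=O)/N=C(\N)N/N=C/C#Cc2ccccc2)c(SCc2ccc(Cl)cc2)cc1Cl` shares the hydrazone of compound 1 but its core differs in the benzylsulfanyl part: 4-chlorophenyl in place of 2-chlorophenyl on a saturated chain carbon bound to a sulfur. The step is a 5.0-fold lower number from compound 1 to compound 3 (0.70 log units; beyond the scatter), and compound 3 in this assay gives 5000 nM, the lowest number of the three, with compound 2 a further distance still.

Compound 4 `C/C(C#Cc1ccccc1)=N\N/C(N)=N/S(=O)(=O)c1cc(C)c(Cl)cc1SCc1ccc(Cl)cc1` is not yet measured. Relative to compound 3 the change is a group of 11 heavy atoms (10 carbon, 1 nitrogen; one six-membered aromatic ring of carbon only) in place of a group of 10 heavy atoms (9 carbon, 1 nitrogen; one six-membered aromatic ring of carbon only), on an amine nitrogen, the same change as from compound 1 to compound 2, made on the same kind of amine nitrogen with the same neighbour, so the step is treated as the same kind. Going by the values given here, only one example of this change exists, so its transfer to the other core is an assumption. The expected step from compound 3 to compound 4 in this assay is an 11-fold higher number from compound 3 to compound 4 (1.04 log units; beyond the scatter), close to the earlier one, because a 14-fold higher number from compound 1 to compound 2 (1.13 log units; beyond the scatter) was large and beyond the scatter. On that basis compound 4 in this assay is estimated at 55000 nM, likely between 15000 nM and 250000 nM.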

Compound 4, half-maximal inhibitory concentration: 16000 nM
The estimate for compound 4 lay 3.4-fold (0.54 log units) above the measured number; measured number inside the range.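

In this assay the swap of the group on the amine nitrogen keeps its direction on the second core (a 3.2-fold higher number from compound 3 to compound 4 (0.51 log units; beyond the scatter)) but not its size: the same change on two cores in this assay, a 14-fold higher number (1.13 log units; beyond the scatter) from compound 1 to compound 2 and a 3.2-fold higher number (0.51 log units; beyond the scatter) from compound 3 to compound 4, 4.3-fold (0.63 log units) apart, beyond the scatter of two such steps.

The swap of 4-chlorophenyl in place of 2-chlorophenyl on a saturated chain carbon bound to a sulfur behaves in the same way, again keeping its direction (a 21-fold lower number from compound 2 to compound 4 (1.33 log units; beyond the scatter)) while its size differs with the group on the amine nitrogen: the same change on two cores in this assay, a 5.0-fold lower number (0.70 log units; beyond the scatter) from compound 1 to compound 3 and a 21-fold lower number (1.33 log units; beyond the scatter) from compound 2 to compound 4, 4.3-fold (0.63 log units) apart, beyond the scatter of two such steps.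

For these four compounds, then, the direction of each change carried from one core to the other and the size did not, so a step measured on one core gives only a rough guide on the other; the numbers do not show why the sizes differ, nor whether the direction would hold on any further core.

The compounds shown leave open how the read-out would respond to a longer chain in the group on the amine nitrogen, or to an unsubstituted phenyl or a fluorophenyl in place of the chlorophenyl. They also leave open whether the gap between the steps would persist with those groups, since each change here rests on a single pair of cores.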